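Methylated Imidazole in Place of a Free Imidazole

A few compounds are considered here, and "the series" means these few. Any claim that something is new, unique, unknown or untested is made for them only; others in the source may bear on it.

Of the compounds shown here, two have so far been measured in a physicochemical assay for solubility, at pH 7.4; a lower number here means a less soluble compound, a higher number a more soluble compound. Compound 1 `Cc1ccc(NC(=O)c2cccc(N(C)C)c2)cc1NC(=O)c1ccc(OC(C)C)cc1` gives there only a limit of the assay, < 1000 nM. Compound 2 `Cc1ccc(-c2c[nH]cn2)cc1NC(=O)c1ccc(OCc2ccccn2)cc1` gives in this assay a measured value of 90000 nM. Within the data shown here, compound 2 therefore stands at the only actual number in the set; the remaining entry is a limit, (the limit of < 1000 nM in this assay, at which 1 of the 2 values shown sits). Compound 3 `Cc1ccc(-c2nccn2C)cc1NC(=O)c1ccc(OCc2ccccn2)cc1` has not yet been measured. It differs from compound 2 by 1-methyl-1H-imidazol-2-yl in place of 1H-imidazol-4-yl on an aromatic carbon. Among the measured compounds shown here, no step between measured compounds that differ in one place exists to guide this change, and compounds 1 and 2 differ in several places, so only their two values can be set side by side. The change from compound 2 to compound 3 is expected to bring a modest fall in solubility, a 1.8-fold lower number from compound 2 to compound 3 (0.26 log units; within the scatter), although an outcome within the usual scatter would not surprise. Compound 3 is accordingly estimated at 50000 nM in this assay, with a likely range from 15000 nM to 150000 nM.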

Compound 3, solubility: 190000 nM
Beside the measured number, compound 3's estimate is 3.8-fold (0.58 log units) below it; measured number above the stated range.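

In this assay, this position, on an aromatic carbon para to a methyl group, now has its first step between compounds that differ in one place: 1-methyl-1H-imidazol-2-yl in place of 1H-imidazol-4-yl gives a 2.1-fold higher number from compound 2 to compound 3 (0.32 log units; beyond the scatter) in a modest move. The entering group is the larger one and has no hydrogen-bond donor, yet the number went up rather than down, so this exchange carries no cost in this read-out. Nothing at hand bears on the reason for this step.

This single step changes the added methyl and the point of attachment of the ring together, and it cannot tell which of the two matters. On these data alone, how a ring of another kind, such as a pyridine, or an open amine at this position would read in this assay stays open.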